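Removing one methyl from a gem-dimethyl BHMT inhibitor

This account rests on a few compounds, and the source may have more. Where it says the series, first, only, none or still open, it means among the compounds named here.

Compound 1 `CC(C)(CCSCCC(N)C(=O)O)CC(=O)O`: 84 nM
Compound 2 `CC(C)(CCSCC[C@H](N)C(=O)O)CC(=O)O`: 64 nM
Compound 3 `CC(C)(CCSCC[C@@H](N)C(=O)O)CC(=O)O`: 701 nM

In an assay for inhibition of betaine--homocysteine S-methyltransferase 1 (Homo sapiens) (on this read-out higher numbers stand for weaker inhibition and lower numbers for stronger inhibition), compound 1 gives 84 nM and stands second highest of the three numbers. Its nearest neighbour is compound 2, with a 1.3-fold lower number from compound 1 to compound 2 (0.12 log units; within the scatter); the two are drawn with the same atoms and bonds, and differ only in that one stereocentre is drawn without a configuration in compound 1 and S in compound 2 (the fact that one of compounds 1 and 2 is drawn with a defined configuration and the other without, at the place where they differ). The largest gap is to compound 3, with an 8.3-fold higher number from compound 1 to compound 3 (0.92 log units; beyond the scatter), again the same atoms and bonds, the stereocentre drawn R in compound 3 (the fact that one of compounds 1 and 3 is drawn with a defined configuration and the other without, at the place where they differ). Between the two resolved forms, an 11-fold higher number from compound 2 to compound 3 (1.04 log units; beyond the scatter), which differ only in configuration as drawn (the fact that compounds 2 and 3 differ only in the configuration as drawn).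

Compound 4 `CC(CCSCCC(N)C(=O)O)CC(=O)O` is not yet measured. It differs from compound 1 by hydrogen in place of methyl on a saturated chain carbon bound to three saturated chain carbons. For the measured compounds named here, none of the measured steps touches this part of the molecule: all three concern the configuration at the amino-acid carbon, and the carbon carrying the methyls is left untouched. Since there is no measured change of this kind, the expectation is that the step of a 1.8-fold higher number from compound 1 to compound 4 (0.25 log units; within the scatter) is no larger than modest, in either direction. Compound 4 is therefore estimated at 150 nM, with a range from 40 nM to 600 nM.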

Compound 4, half-maximal inhibitory concentration: 139 nM
Estimate against measurement, compound 4: 1.1-fold (0.03 log units) above; the range from low to high includes it.
By their numbers in this assay, from the lowest: compounds 2, 1 and 4 (each within the scatter of the next, the first and the last beyond it); then compound 3.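

For the compounds shown here, the earlier compounds changed only the configuration at the amino-acid carbon, so this is the first look at the carbon carrying the two methyls. In this assay, hydrogen in place of methyl on this saturated chain carbon bound to three saturated chain carbons gives a 1.7-fold higher number from compound 1 to compound 4 (0.22 log units; within the scatter), so the two numbers cannot be told apart and the second methyl is not needed to keep the number in this range. The facts at hand concern only configuration at the amino-acid carbon and none bears on this step, so no cause can be given for it.

On these data alone, compound 4 is drawn without a configuration at the amino-acid carbon, as compound 1 is, and the carbon that keeps one methyl now carries two different chains and is a further stereocentre drawn without a configuration, so what each resolved form would give stays open. Also open, as far as these compounds go, is whether an ethyl or a hydroxyl at this place, or hydrogen in place of the remaining methyl, would stay as close to compound 1.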